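The compounds below may be only part of what the source reports. "The series", "measured", "known", "first", "only" and "open" are said of these compounds alone.

Measured so far:
compound 1 `O=C(NCCCCc1ccccc1)c1cccc(C2SCC(=O)N2c2cccc(-c3c[nH]nn3)c2)c1` gives 110 nM
compound 2 `COc1ccc(F)cc1N1C(=O)CSC1c1cccc(C(=O)NCCCCn2cccn2)c1` gives 97.3 nM
compound 3 `O=C(NCCCCc1ccccc1)c1cc(F)cc(C2SCC(=O)N2c2ccccn2)c1` gives 14.2 nM

In a functional assay on HOS-TE85 cells (Homo sapiens) for inhibition, read by CCK-8 assay, with a stated time of 72 h (on this read-out lower numbers stand for stronger inhibition and higher numbers for weaker inhibition), compound 1 stands at the highest of the three numbers. Compound 2 lies within the usual scatter of compound 1, so the two cannot be separated. Compound 3 gives a lower number than compound 1, and that gap lies beyond the scatter.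

Compound 4 `O=C(NCCCCc1ccccc1)c1cccc(C2SCC(=O)N2c2nccs2)c1` is not yet measured. It differs from compound 1 in one place: a group of 5 heavy atoms (3 carbon, 1 nitrogen, 1 sulfur; one five-membered aromatic ring with 2 hetero atoms) in place of a group of 11 heavy atoms (8 carbon, 3 nitrogen; one five-membered aromatic ring with 3 hetero atoms, one six-membered aromatic ring of carbon only), on an amide-type nitrogen in a ring. Among the measured compounds shown here, no pair of measured compounds shows this change on its own, so its effect cannot be read from a measured step. Compound 3 shows that lower numbers are reachable in the series, but it differs from compound 1 in more than one place, so it gives only loose guidance. For compound 4 a modest step toward a lower number is expected, estimated as a 1.8-fold lower number from compound 1 to compound 4 (0.26 log units; within the scatter) in this assay, with a real chance that it stays within the scatter. Compound 4 is accordingly estimated at 60 nM in this assay, with a likely range from 15 nM to 250 nM.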

Compound 4, half-maximal inhibitory concentration: > 1000 nM
Compound 4: only a limit was reported (the forecaster's own chance of this, stated with the estimate: 2%); middle value at least 16-fold (1.22 log units) from the limit.
By their numbers in this assay, from the lowest: compound 3; then compounds 2 and 1 (each within the scatter of the next). At a limit, above all of these: compound 4.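

In this assay, the swap of the group of 11 heavy atoms for 1,3-thiazol-2-yl, on the amide-type nitrogen in a ring, gives an at least 9.0-fold higher number from compound 1 to compound 4 (0.95 log units; beyond the scatter). Compound 4 carries a limit and not a number: the limit of > 1000 nM in this assay, at which 1 of the 4 values shown sits. Among the compounds shown here, this is the first single-place step, and it shows that the group on this nitrogen can move the number beyond the scatter, which no earlier pair could show.

The step changes the whole group at once, so it leaves open whether the six-membered carbon ring, the five-membered ring with 3 hetero atoms or the hydrogen-bond donor accounts for the difference. An unsubstituted phenyl or a 1,3-oxazol-2-yl on this nitrogen, with the rest of compound 1 kept, would help to separate these parts.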